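The compounds below may be only part of what the source reports. "The series", "measured", "known", "first", "only" and "open" are said of these compounds alone.

Measured compounds:
Compound 1, `c1ccc(C(=NNc2nc3ccccc3o2)c2ccccn2)nc1`, gives 6980 nM in a functional assay on HT-29 cells (Homo sapiens) for antiproliferative activity, read by sulforhodamine B assay; a lower number here means a stronger inhibitor, a higher number a weaker inhibitor.
Compound 2, `CC(C)/C(=N\Nc1nc2ccccc2o1)c1ccccn1`, gives 645 nM.
Compound 3, `C/C(=N\Nc1nc2ccccc2o1)c1nccnc1C`, gives 2140 nM.

Compound 2 holds the lowest of the three numbers in this assay. Compound 3 is the nearest to it and compound 1 the furthest, and both gaps lie beyond the usual scatter of repeated measurements. Compound 4, `CCC/C(=N\Nc1nc2ccccc2o1)c1ccccn1`, has not yet been measured in this assay. It differs from compound 2 in one place: propyl in place of isopropyl on a carbon with a double bond to nitrogen. Within the data shown here, none of the three measured compounds differs from another in only one place, so no measured step shows how rearranging the same three carbons on this carbon shifts the number. The estimate therefore rests on compound 2 alone, whose value of 645 nM is the starting point. A step of modest size is expected, most likely a small loss or none beyond the scatter, giving a 1.4-fold higher number from compound 2 to compound 4 (0.14 log units; within the scatter). Compound 4 is thus estimated at 900 nM, with a plausible range from 350 nM to 2500 nM.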

Compound 4, half-maximal inhibitory concentration: 851 nM
Compound 4: the middle estimate sits 1.1-fold (0.02 log units) above what was measured; the range from low to high includes it.
By their numbers in this assay, from the lowest: compounds 2 and 4 (each within the scatter of the next); then compound 3; then compound 1.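

In this assay, this pair gives the first direct reading at this position: moving from isopropyl to propyl on a carbon with a double bond to nitrogen gives a 1.3-fold higher number from compound 2 to compound 4 (0.12 log units; within the scatter), the first step between any two of the compounds shown. Rearranging the same three carbons therefore leaves the two numbers within the scatter of each other, so this pair does not separate the two groups at this position. Nothing measured on these compounds offers an explanation for this result.

On these data alone, it remains open whether an ethyl group, a longer chain such as butyl, a cyclopropyl ring or an amine on this carbon would keep the number in the same range. As far as these compounds go, the change is also seen in this one pair only, so its effect with a different aromatic group on the same carbon is unknown.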